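Bromo Added to the Dimethoxy Analogue of the Shared Core

The compounds below may be only part of what the source reports. "The series", "measured", "known", "first", "only" and "open" are said of these compounds alone.

Measured so far:
compound 1, `COc1ccc(C2CC(c3ccccc3)=NN2C2=NC(=O)/C(=C3\C(=O)Nc4ccccc43)S2)cc1`, 4390 nM
compound 2, `COc1ccc(C2CC(c3ccccc3)=NN2C2=NC(=O)/C(=C3\C(=O)Nc4ccc(Br)cc43)S2)cc1`, 390 nM
compound 3, `COc1ccc(C2=NN(C3=NC(=O)/C(=C4\C(=O)Nc5ccccc54)S3)C(c3ccc(OC)cc3)C2)cc1`, 100000 nM

Of the compounds shown here, three built on one shared core have been tested in a functional assay on cells (Cancer cell lines, Homo sapiens) for cytotoxicity, read by sulforhodamine B assay, with a stated time of 48 h; a lower number here means a stronger inhibitor of growth, a higher number a weaker inhibitor of growth. Compound 3 stands at the highest number of the three: the measured step is a 23-fold higher number from compound 1 to compound 3 (1.36 log units; beyond the scatter), and against compound 2 its value and 390 nM lie far apart, so compound 3 is the weakest growth inhibitor of the measured set.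

Compound 4, `COc1ccc(C2=NN(C3=NC(=O)/C(=C4\C(=O)Nc5ccc(Br)cc54)S3)C(c3ccc(OC)cc3)C2)cc1`, has not yet been measured. It differs from compound 3 in one place: bromo in place of hydrogen on an aromatic carbon. Within the data shown here, the only measured step of the same kind is the one on the unsubstituted pair, an 11-fold lower number from compound 1 to compound 2 (1.05 log units; beyond the scatter), a large shift toward stronger inhibition. Among the measured compounds shown here, no step of that kind has been measured on a methoxy-bearing partner, so whether it carries over unchanged is open; nonetheless the one precedent points in one direction.

Compound 4 is therefore expected to show a step of about an 8.3-fold lower number from compound 3 to compound 4 (0.92 log units; beyond the scatter) in this assay, toward a lower number. The estimated value for compound 4 is 12000 nM, with a range from 3000 nM to 60000 nM.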

Compound 4, concentration for total growth inhibition: 25300 nM
Compound 4: the middle estimate sits 2.1-fold (0.32 log units) below what was measured, within the range that was stated.
By their numbers in this assay, from the lowest: compound 2; then compound 1; then compound 4; then compound 3.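

In this assay, bromo on this aromatic carbon, on a six-membered ring that is part of a fused system of two rings, still lowers the number with the methoxy present, giving a 4.0-fold lower number from compound 3 to compound 4 (0.60 log units; beyond the scatter) in this second pair, so the direction of the first step holds but its size does not carry over: the same change on two cores in this assay, an 11-fold lower number (1.05 log units; beyond the scatter) from compound 1 to compound 2 and a 4.0-fold lower number (0.60 log units; beyond the scatter) from compound 3 to compound 4, 2.8-fold (0.45 log units) apart, beyond the scatter of two such steps.

Seen from the other side, methoxy in place of hydrogen still raises the number when bromo is already present, giving a 65-fold higher number from compound 2 to compound 4 (1.81 log units; beyond the scatter) on the brominated partner, and this step also differs in size from its counterpart without bromo: the same change on two cores in this assay, a 23-fold higher number (1.36 log units; beyond the scatter) from compound 1 to compound 3 and a 65-fold higher number (1.81 log units; beyond the scatter) from compound 2 to compound 4, 2.8-fold (0.45 log units) apart, beyond the scatter of two such steps.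

Across these four compounds, the two changes therefore do not act independently, since the gain from bromo is smaller with the methoxy present and the loss from methoxy is larger with the bromo present.

The compounds shown carry only bromo at this position, so it remains open whether chloro, nitro or an amine there would give a larger or smaller step. They also leave open whether the same dependence between the two changes would appear with hydroxy or ethoxy in place of the methoxy.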